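The compounds below may be only part of what the source reports. "The series", "measured", "known", "first", "only" and "open" are said of these compounds alone.

Measured in a functional assay on A549 cells (Homo sapiens) for antiproliferative activity, read by MTT assay, with a stated time of 48 h; on this read-out higher numbers stand for weaker inhibition and lower numbers for stronger inhibition:
Compound 1 `CCN(CC)CCCn1c(N)c(-c2nc3ccccc3n2C)c2nc(C#N)c(C#N)nc21` gives 10700 nM.
Compound 2 `CN(C)CCCCn1c(N)c(-c2nc3ccccc3n2C)c2nc(C#N)c(C#N)nc21` gives 6150 nM.
Compound 3 `CCN(CC)CCCn1c(N)c(-c2nc3cc(Cl)ccc3[nH]2)c2nc(C#N)c(C#N)nc21` gives only a limit of the assay, > 50000 nM.

The amine at the chain end is exchanged in (dimethylamino)methyl in place of diethylamino on a saturated chain carbon, three bonds along the chain from an aromatic nitrogen, and this gave a 1.7-fold lower number from compound 1 to compound 2 (0.24 log units; within the scatter). The two cores differ as counted in 5-chloro-1H-benzimidazol-2-yl in place of 1-methyl-1H-benzimidazol-2-yl on an aromatic carbon, which gave an at least 4.6-fold higher number from compound 1 to compound 3 (0.66 log units; beyond the scatter), leaving compound 3 at the limit of > 50000 nM in this assay, at which 1 of the 3 values shown sits. Compound 4 `CN(C)CCCCn1c(N)c(-c2nc3cc(Cl)ccc3[nH]2)c2nc(C#N)c(C#N)nc21` is the unmeasured partner of compound 3 and carries the same change, ((dimethylamino)methyl in place of diethylamino on a saturated chain carbon, three bonds along the chain from an aromatic nitrogen), at the same place. Because the same exchange produced only a 1.7-fold lower number from compound 1 to compound 2 (0.24 log units; within the scatter) on the other core, compound 4 is expected to remain around the limit, a step of about a number no higher from compound 3 to compound 4 (the limit leaves the size open). The estimate for compound 4 is 50000 nM, expected to fall between 20000 nM and 150000 nM.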

Compound 4, half-maximal inhibitory concentration: 12100 nM
Estimate against measurement, compound 4: 4.1-fold (0.62 log units) above, outside the stated range (below it).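

In this assay, exchanging 3-(diethylamino)propyl for 4-(dimethylamino)butyl on the chloro-bearing core gives an at least 4.1-fold lower number from compound 3 to compound 4 (0.61 log units; beyond the scatter). Compound 3 stands only at a limit of the assay, not at a number, so this step cannot be set exactly beside the one on the other core: the same change on two cores in this assay, a 1.7-fold lower number (0.24 log units; within the scatter) from compound 1 to compound 2 and an at least 4.1-fold lower number (0.61 log units; beyond the scatter) from compound 3 to compound 4; the limit leaves it open whether they differ. Exchanging the core between the two 4-(dimethylamino)butyl compounds gives a 2.0-fold higher number from compound 2 to compound 4 (0.29 log units; within the scatter), and this step likewise cannot be told apart from its partner: the same change on two cores in this assay, an at least 4.6-fold higher number (0.66 log units; beyond the scatter) from compound 1 to compound 3 and a 2.0-fold higher number (0.29 log units; within the scatter) from compound 2 to compound 4; the limit leaves it open whether they differ.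

The compounds shown leave open whether the amine exchange really has a different size on the two cores. They also leave open how a morpholine at the chain end, or a longer chain, would read in this assay.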